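The source may report more compounds than this note shows. Statements on the series, on what has been measured and on what is new or still open speak of the compounds shown alone.

Working notes on the diaryl ether urea series. Compound 3 `O=C(Nc1ccccc1)Nc1ccc(Oc2ccc(-c3ncc[nH]3)cc2)cc1` stands lowest of the two numbers available in a functional assay on A549 cells (Homo sapiens) for inhibition, read by MTT assay and WST assay, with a stated time of 72 h, tested at 10 uM; a lower number here means less inhibition of growth, a higher number more inhibition of growth at the concentration tested: compound 3 gives 7.09%, while compound 2 `O=C(Nc1ccc(Oc2ccc(-c3nccs3)cc2)cc1)Nc1ccc(Cl)c([N+](=O)[O-])c1` gives 77.1%, a gap beyond the scatter. Compound 2 and compound 3 differ in more than one place, so the gap cannot be assigned to either change. For compound 1 `O=C(Nc1ccccc1)Nc1ccc(Oc2ccc(-c3nccs3)cc2)cc1` the entry in this assay reads "not determined" (no result reported).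

Compound 4 `O=C(Nc1ccc(Oc2ccc(-c3ncc[nH]3)cc2)cc1)Nc1ccc(F)c(C(F)(F)F)c1` differs from compound 3 in one place: 4-fluoro-3-(trifluoromethyl)phenyl in place of phenyl on an amide-type nitrogen. For the measured compounds named here, no single-point step between measured compounds exists to calibrate this change. The only substituted aryl urea with a number, compound 2, sits high, but it also carries a different shared core, so it is weak support. The expected step in this assay from compound 3 to compound 4 is an increase of moderate size, a number 22.9 percentage points higher from compound 3 to compound 4 (beyond the scatter), with wide uncertainty. Compound 4 is therefore estimated at 30%, between 5% and 65%.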

Compound 4, percent growth inhibition at one concentration: 63.3%
The estimate for compound 4 lay 33.3 percentage points below the measured number; measured number inside the range.
By their numbers in this assay, from the lowest: compound 3; then compound 4; then compound 2.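

In this assay, the position on an amide-type nitrogen whose other neighbour is the carbonyl carbon responds strongly on the core of compound 3: 4-fluoro-3-(trifluoromethyl)phenyl in place of phenyl gives a number 56.2 percentage points higher from compound 3 to compound 4 (beyond the scatter). This is the only single-place step among the compounds shown, so this one change can now be read on its own, unlike the gap between compound 2 and compound 3, and it holds for this core only. No measured evidence bears on the size of this step.

Open, from the compounds shown here alone, is which part of the entering group carries the step, the fluorine or the trifluoromethyl, and whether a phenyl bearing an amine or a carboxylic acid, or a longer alkyl chain, on this nitrogen would give a similar number. Also open, going by these compounds, is whether the same change would act alike on the core of compound 1, where compound 1 reads "not determined" (no result reported).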